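Removing the ester from compound 1

The source may report more compounds than this note shows. Statements on the series, on what has been measured and on what is new or still open speak of the compounds shown alone.

Measured so far in a functional assay on SGC-7901 cells (Homo sapiens) for antiproliferative activity, read by MTT assay, with a stated time of 72 h; on this read-out higher numbers stand for weaker inhibition and lower numbers for stronger inhibition:
- Compound 1 `CCOC(=O)c1cc(-c2ccc(OC)cc2)c(-c2cc(OC)c(OC)c(OC)c2)s1` gives 6820 nM
- Compound 2 `CCOC(=O)c1cc(-c2ccc(OC)c(OCc3ccccc3)c2)c(-c2cc(OC)c(OC)c(OC)c2)s1` gives > 100000 nM, which is a limit of the assay

Among the measured compounds shown here, compound 1 holds the only exact number so far, since the result for compound 2 is a limit. Compound 3 `COc1ccc(-c2ccsc2-c2cc(OC)c(OC)c(OC)c2)cc1` carries hydrogen in place of ethoxycarbonyl on an aromatic carbon of compound 1 (hydrogen in place of ethoxycarbonyl on an aromatic carbon). For the measured compounds named here, the only measured step, an at least 14-fold higher number from compound 1 to compound 2 (1.16 log units; beyond the scatter), was large, but it involved a different group at a different place, so it does not set the size or direction here. No shift beyond the scatter is therefore expected in this assay, though the uncertainty is wide. The estimated step is a 1.4-fold lower number from compound 1 to compound 3 (0.13 log units; within the scatter). For compound 3 the expected value is 5000 nM, with an estimated range from 500 nM to 50000 nM.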

Compound 3, half-maximal inhibitory concentration: 2740 nM
Beside the measured number, compound 3's estimate is 1.8-fold (0.26 log units) above it; measured number inside the range.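

In this assay, the ethoxycarbonyl group next to the ring sulfur proves unnecessary for activity on these cells: a 2.5-fold lower number from compound 1 to compound 3 (0.40 log units; beyond the scatter). So this position tolerates losing the whole group, and bare hydrogen there gives the modestly stronger result, something the earlier step, made at a different place, could not show. Nothing measured here explains why the number moves. Going by these compounds, how other groups would behave at this position remains open: a carboxylic acid, an amide or a methyl group could fall on either side of compound 3.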